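A few compounds are considered here, and "the series" means these few. Any claim that something is new, unique, unknown or untested is made for them only; others in the source may bear on it.

Measured so far:
compound 1, `CC(C)C[C@H](O)C(=O)NS(=O)(=O)OC[C@H]1O[C@@H](n2cnc3c(N)ncnc32)[C@H](O)[C@@H]1O`, in a functional assay on HCT-116 cells (Homo sapiens) for antiproliferative activity, read by sulforhodamine B assay, with a stated time of 72 h; a lower number here means a stronger inhibitor, a higher number a weaker inhibitor: 3470 nM
compound 2, `CO[C@H](C(=O)NS(=O)(=O)OC[C@H]1O[C@@H](n2cnc3c(N)nc(Cl)nc32)[C@H](O)[C@@H]1O)[C@H](OC)C(C)C`, in this assay: > 20000 nM
compound 3, `CC(C)[C@@H](O)[C@H](O)C(=O)NS(=O)(=O)OC[C@H]1O[C@@H](n2cnc3c(=O)[nH]cnc32)[C@H](O)[C@@H]1O`, in this assay: > 20000 nM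

Compound 3 gives no number in this assay, only a limit, > 20000 nM, and that is the limit of > 20000 nM in this assay, at which 2 of the 3 values shown sit. Compound 2 likewise gives only a limit in this assay, > 20000 nM. Compound 1 alone gives a number, 3470 nM, so compound 3 stands at the weak end of what has been measured, with no number to place it more closely.

The next compound is compound 4, `CC(C)C[C@H](O)C(=O)NS(=O)(=O)OC[C@H]1O[C@@H](n2cnc3c(=O)[nH]cnc32)[C@H](O)[C@@H]1O`. It differs from compound 3 in one place: hydrogen in place of hydroxy on a saturated chain carbon bound to two saturated chain carbons. No step between two measured compounds covers this change, so its size cannot be read from the numbers shown. Compound 1 carries the same isobutyl chain on a different core and gives 3470 nM. Compound 3, by contrast, gives only a limit. The core differs between these two compounds, so this is only a loose pointer. A step from the limit towards a number, beyond the scatter, is expected, but with a real chance that compound 4 also stops at the limit. The expected step is an at least 1.6-fold lower number from compound 3 to compound 4 (0.22 log units; that floor lies within the scatter). Compound 4 is estimated at 12000 nM, within 3000 nM to 40000 nM.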

Compound 4, half-maximal inhibitory concentration: > 20000 nM
Compound 4 was reported as a limit; the forecaster's own chance of this, stated with the estimate: 45%; middle value at least 1.6-fold (0.22 log units) from the limit.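

Compound 4 gives only a limit in this assay, > 20000 nM, and that limit now holds most of the set: the limit of > 20000 nM in this assay, at which 3 of the 4 values shown sit.

The exchange of 1-hydroxy-2-methylpropyl for isobutyl, hydrogen in place of hydroxy on a saturated chain carbon bound to two saturated chain carbons, therefore brings no number on this core, and the step between the two limits cannot be read. Going by these compounds alone, with the isobutyl chain held fixed, the change of core alone gives an at least 5.7-fold higher number from compound 1 to compound 4 (0.76 log units; beyond the scatter), the first readable step, so in this assay the isobutyl chain by itself does not secure a number.

As far as these compounds go, how far compound 3 and compound 4 lie past the limit stays open, as does the effect of the same hydroxy-to-hydrogen change on the core of compound 1. Also open, from the compounds shown here alone, is whether a longer chain in place of isobutyl, or an amine on that chain, would bring the core of compound 4 back to a number.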